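Tolerated concentration in HEL cells: compound 2 to compound 4

The compounds below may be only part of what the source reports. "The series", "measured", "known", "first", "only" and "open" are said of these compounds alone.

Of the compounds shown here, three have been read in an ADME assay on HEL cells (Homo sapiens) for cytotoxicity, read by microscopy; a higher number here means that more compound is tolerated, a lower number that less compound is tolerated. Compound 1 `O=c1ccn(CCCCOc2ccc(Br)cc2)c(=O)[nH]1` gives 100000 nM. Compound 3 `O=c1ccn(CCCOc2ccc(Br)cc2)c(=O)[nH]1` returns only a limit of the measurement, > 100000 nM. Compound 2 `CCCOC(=O)c1ccc(OCCCCCn2ccc(=O)[nH]c2=O)cc1` likewise returns a limit rather than a number, >= 100000 nM. Compound 2 therefore stands at the top of the range covered, where the other two values also sit (the limit of > 100000 nM in this assay, at which 1 of the 3 values shown sits, (the limit of >= 100000 nM in this assay, at which 1 of the 3 values shown sits)). For the measured compounds named here, no two measured compounds differ in a single place, so no measured step is available. Compound 4 `O=c1ccn(CCCCCOc2ccccc2)c(=O)[nH]1` differs from compound 2 by hydrogen in place of propoxycarbonyl on an aromatic carbon. With all three measured values at one level, the expected step is a number no higher from compound 2 to compound 4 (the limit leaves the size open), none beyond the scatter. Compound 4 is estimated at 100000 nM, within 50000 nM to 100000 nM, most probably again as a limit.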

Compound 4, minimum cytotoxic concentration: > 100000 nM
Compound 4: no number, only a limit; the forecaster's own chance of this, stated with the estimate: 70%; the middle value sits exactly at the limit.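

Compound 2 and compound 4 both return only limits, and no step can be read between them for hydrogen in place of propoxycarbonyl. The compounds shown leave open whether this exchange changes the tolerated concentration at all.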